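A few compounds are considered here, and "the series" means these few. Any claim that something is new, unique, unknown or untested is made for them only; others in the source may bear on it.

Within the data shown here, the three compounds measured so far share one core and differ only in the ring attached to the amide-type nitrogen. Compound 1 `O=C(Nc1cccc(Br)c1)N1CCN(c2ccnc(Cl)n2)CC1` carries a 3-bromophenyl there; in an assay on isolated protein for antagonist activity at transient receptor potential cation channel subfamily V member 1 (Homo sapiens) (a higher number here means a weaker inhibitor, a lower number a stronger inhibitor), compound 1 gives 1450 nM. Compound 2 `O=C(Nc1ccccc1F)N1CCN(c2ccnc(Cl)n2)CC1` carries a 2-fluorophenyl, and in this assay compound 2 gives 787 nM. Compound 3 `O=C(Nc1cccc(F)c1)N1CCN(c2ccnc(Cl)n2)CC1` carries a 3-fluorophenyl, and in this assay compound 3 gives 952 nM. Among these three numbers compound 3 stands second highest, yet all three lie within the usual scatter of one another: a 1.5-fold lower number from compound 1 to compound 3 (0.18 log units; within the scatter), a 1.2-fold higher number from compound 2 to compound 3 (0.08 log units; within the scatter) and a 1.8-fold lower number from compound 1 to compound 2 (0.27 log units; within the scatter). Compound 4 `O=C(Nc1ccc(F)cc1)N1CCN(c2ccnc(Cl)n2)CC1` is the next compound to be tested; it is made of the same atoms as compound 3, joined differently: 4-fluorophenyl in place of 3-fluorophenyl on an amide-type nitrogen. The step that bears most directly on this change is the one in which the fluorine was moved on the same ring, a 1.2-fold higher number from compound 2 to compound 3 (0.08 log units; within the scatter), and the remaining measured step, a 1.8-fold lower number from compound 1 to compound 2 (0.27 log units; within the scatter), was likewise small. Moving the fluorine once more is therefore expected to give no step beyond the scatter in this assay, a 1.1-fold lower number from compound 3 to compound 4 (0.02 log units; within the scatter). Compound 4 is thus estimated at 900 nM, with a likely range from 450 nM to 1800 nM.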

Compound 4, half-maximal inhibitory concentration: 1140 nM
Estimate against measurement, compound 4: 1.3-fold (0.10 log units) below; the range from low to high includes it.
By their numbers in this assay, from the lowest: compounds 2, 3, 4 and 1 (each within the scatter of the next).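

With compound 4, a single fluorine has now been placed at each of the ring positions named by 2-fluorophenyl, 3-fluorophenyl and 4-fluorophenyl, so this position on the amide-type nitrogen can be compared across all three arrangements. In this assay, 4-fluorophenyl stays within the scatter both against 3-fluorophenyl (a 1.2-fold higher number from compound 3 to compound 4 (0.08 log units; within the scatter)) and against 2-fluorophenyl (a 1.4-fold higher number from compound 2 to compound 4 (0.16 log units; within the scatter)), and exchanging 3-bromophenyl for 4-fluorophenyl, which alters both the halogen and its place on the ring, also stays within it (a 1.3-fold lower number from compound 1 to compound 4 (0.10 log units; within the scatter)), so no change of halogen or of its place separates any of these four compounds. No measurement is available that would explain why this series looks so flat.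

On these data alone, every ring varied so far carries one halogen, so it remains open whether a different group on the phenyl ring, such as methoxy, trifluoromethyl or an amine, or a phenyl ring with nothing on it, would give a step beyond the scatter. As far as these compounds go, the shared core has stayed fixed throughout, so it is equally open what would follow if its chlorine gave way to a group such as an amine or a methyl.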